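Compound 2 and the acetamido-to-amino step

The source may report more compounds than this note shows. Statements on the series, on what has been measured and on what is new or still open speak of the compounds shown alone.

In an ADME assay on MT4 cells (Homo sapiens) for cytotoxicity, read by MTT assay, with a stated time of 4 days (a lower number here means that less compound is tolerated, a higher number that more compound is tolerated), compound 1 (`CC(=O)Nc1ccc2oc(-c3ccccc3)cc(=O)c2c1`) gives 184000 nM, compound 2 (`CC(=O)Nc1ccc2oc(-c3ccccc3)c(O)c(=O)c2c1`) gives 64700 nM and compound 3 (`COc1ccc(-c2oc3ccc(NC(C)=O)cc3c(=O)c2O)cc1`) gives 98700 nM. Compound 2 thus lies within the scatter of compound 3 and beyond the scatter under compound 1.

Compound 4 (`Nc1ccc2oc(-c3ccccc3)c(O)c(=O)c2c1`) differs from compound 2 by hydrogen in place of acetyl on a nitrogen on an aromatic ring. Neither measured step involves that nitrogen, so the evidence is indirect. The hydroxy step is a 2.8-fold lower number from compound 1 to compound 2 (0.45 log units; beyond the scatter) and is modest. The methoxy step is a 1.5-fold higher number from compound 2 to compound 3 (0.18 log units; within the scatter) and stays within the scatter. Going by the values given here, with no measured acetamido-to-amino pair, these two sizes are the only guide, and no step beyond the scatter is expected in this assay for this change. The expected step is a 1.3-fold lower number from compound 2 to compound 4 (0.13 log units; within the scatter). For compound 4 the estimated value is 48000 nM, with an expected range from 18000 nM to 120000 nM.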

Compound 4, half-maximal cytotoxic concentration: 217000 nM
The estimate for compound 4 lay 4.5-fold (0.66 log units) below the measured number; measured number above the stated range.
By their numbers in this assay, from the lowest: compounds 2, 3, 1 and 4 (each within the scatter of the next, the first and the last beyond it).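

On a nitrogen on an aromatic ring, hydrogen in place of acetyl gives in this assay a 3.4-fold higher number from compound 2 to compound 4 (0.53 log units; beyond the scatter) and so more compound is tolerated after the acetyl leaves. Going by these compounds alone, the hydroxy and methoxy steps left this nitrogen untouched; this step, beyond the scatter, is the first direct reading at this place and shows that acetamido to amino registers in this assay. No measurement shown accounts for the direction or size of the step.

Going by these compounds, this change is read on a single pair only, so whether it holds without the hydroxy of compound 2, or with the methoxy of compound 3, stays open. Also open, on these data alone, is how a longer acyl chain, a methanesulfonyl group or a dimethylamino group on this nitrogen would compare with acetamido and amino.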